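The source may hold more compounds than are shown below. What is called first, only, known or untested is meant among the compounds shown, and "the series" means these compounds.

Measured compounds:

Compound 1 `Nc1ncn(CCC2(N)OC(=O)C(OCc3ccccc3)=C2OCc2ccccc2)c(=O)n1`: in a functional assay on HeLa cells (Homo sapiens) for inhibition, read by MTT assay, with a stated time of 72 h (on this read-out lower numbers stand for stronger inhibition and higher numbers for weaker inhibition), compound 1 gives > 100000 nM, which is a limit of the assay.
Compound 2 `NC1(CCn2c(=O)[nH]c(=O)[nH]c2=O)OC(=O)C(OCc2ccccc2)=C1OCc1ccccc1`: in this assay compound 2 gives 77100 nM.
Compound 3 `O=C1O[C@H]([C@@H](O)Cn2c(=O)[nH]c(=O)[nH]c2=O)C(OCc2ccccc2)=C1OCc1ccccc1`: in this assay compound 3 gives > 100000 nM, which is a limit of the assay.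

Within the data shown here, the one step measured in the same direction is a group of 8 heavy atoms (3 carbon, 4 nitrogen, 1 oxygen; one six-membered aromatic ring with 3 hetero atoms) in place of a group of 9 heavy atoms (3 carbon, 3 nitrogen, 3 oxygen; one six-membered aromatic ring with 3 hetero atoms), on a saturated chain carbon, two bonds along the chain from a saturated ring carbon. Its size is an at least 1.2-fold higher number from compound 2 to compound 1 (0.11 log units; that floor lies within the scatter); the step is known only as a floor due to the limit of > 100000 nM in this assay, at which 2 of the 3 values shown sit, so the true size from compound 2 to compound 1 is not fixed by the data. Compound 2 and compound 3 share the benzyloxy-bearing lactone, but how the two cores differ is not broken down here.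

The unmeasured compound 4 `Nc1ncn(C[C@H](O)[C@H]2OC(=O)C(OCc3ccccc3)=C2OCc2ccccc2)c(=O)n1` is reached from compound 3 by a group of 8 heavy atoms (3 carbon, 4 nitrogen, 1 oxygen; one six-membered aromatic ring with 3 hetero atoms) in place of a group of 9 heavy atoms (3 carbon, 3 nitrogen, 3 oxygen; one six-membered aromatic ring with 3 hetero atoms), on a saturated chain carbon, two bonds along the chain from an oxygen on a saturated carbon and a saturated ring carbon. This is the same kind of change as that from compound 2 to compound 1, but the surroundings differ: in compound 3 the place is two bonds along the chain from an oxygen on a saturated carbon and a saturated ring carbon, whereas in compound 2 it is two bonds along the chain from a saturated ring carbon only.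

Compound 3 already sits at the limit of the assay, and the measured step from compound 2 to compound 1 points to an at most weaker result, so compound 4 is expected to give a step that the limit leaves unreadable from compound 3 to compound 4, with a second limit the most likely outcome. The estimate for compound 4 in this assay is 160000 nM, within 60000 nM to 500000 nM.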

Compound 4, half-maximal inhibitory concentration: > 100000 nM
Compound 4: only a limit was reported; the forecaster's own chance of this, stated with the estimate: 80%; the middle value is on the limit's open side.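

In this assay compound 4 gives > 100000 nM as a limit of the assay. The step from compound 3 to compound 4 cannot be read, since both compounds stand at a limit: the limit of > 100000 nM in this assay, at which 3 of the 4 values shown sit.

The compounds shown leave open whether exchanging these two groups changes inhibition at all on the core of compound 3, and what the true values of compound 1, compound 3 and compound 4 are.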